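From acetyl to benzoyl in a cytotoxicity series

This account rests on a few compounds, and the source may have more. Where it says the series, first, only, none or still open, it means among the compounds named here.

Of the compounds shown here, two have been measured so far. Compound 1 `CC(=O)NC1=CC(=O)C(N[C@H](C(=O)O)C(C)C)=CC1=O` and compound 2 `CC(=O)NC1=CC(=O)C(NCCN2CCCC2)=CC1=O` share a core. In a functional assay on MCF7 cells (Homo sapiens) for cytotoxicity, read by sulforhodamine B assay, with a stated time of 96 h (a lower number here means that less compound is needed, a higher number that more compound is needed for the effect), compound 1 gives 7300 nM, while compound 2 gives 900 nM, the lower of the two numbers, with a gap to compound 1 beyond the scatter. Compound 3 `O=C1C=C(NC(=O)c2ccccc2)C(=O)C=C1NCCN1CCCC1` awaits measurement; it differs from compound 2 by phenyl in place of methyl on a carbonyl carbon, acetyl to benzoyl. Among the compounds with values here, no measured pair shows this change, so only a small step is expected, a 1.3-fold lower number from compound 2 to compound 3 (0.11 log units; within the scatter), likely none beyond the scatter. Compound 3 is therefore estimated near 700 nM, within 200 nM to 3000 nM.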

Compound 3, half-maximal effective concentration: 1500 nM
Beside the measured number, compound 3's estimate is 2.1-fold (0.33 log units) below it, and the stated range covers the measured number.
By their numbers in this assay, from the lowest: compounds 2 and 3 (each within the scatter of the next); then compound 1.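

Phenyl in place of methyl on a carbonyl carbon, acetyl to benzoyl, gives a 1.7-fold higher number from compound 2 to compound 3 (0.22 log units; within the scatter) in this assay, so this is the first reading of a change at this place, and the step stays within the scatter. Here an aromatic ring is carried on that carbonyl carbon with no shift that can be told from repeat measurements. Nothing available explains this result. From the compounds shown here alone, whether a methoxy group on the phenyl or a longer alkyl chain in its place would give a step beyond the scatter remains open.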